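The source may hold more compounds than are shown below. What is called first, only, known or untested is meant among the compounds shown, and "the series" means these compounds.

Three compounds have been measured in a functional assay on A549 cells (Homo sapiens) for antiproliferative activity, read by MTT assay, with a stated time of 24 h; on this read-out higher numbers stand for weaker inhibition and lower numbers for stronger inhibition:

compound 1 `O=c1[nH]cc(S(=O)(=O)Nc2ccccc2-c2cn(-c3ccc(Cl)cc3)nn2)c(=O)[nH]1`, 1180 nM
compound 2 `O=c1[nH]cc(S(=O)(=O)Nc2cccc(-c3cn(-c4ccccc4Cl)nn3)c2)c(=O)[nH]1`, 2730 nM
compound 3 `Cc1cccc(-n2cc(-c3ccc(NS(=O)(=O)c4c[nH]c(=O)[nH]c4=O)cc3)nn2)c1`, 6960 nM

Among these three, compound 3 stands at the highest number. Its nearest neighbour is compound 2, which gives 2730 nM in this assay, a gap beyond the usual scatter; the furthest is compound 1, which gives 1180 nM, a still wider gap. Compound 3 is thus the weakest inhibitor of the three.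

Compound 4 `O=c1[nH]cc(S(=O)(=O)Nc2ccc(-c3cn(-c4ccc(Cl)cc4)nn3)cc2)c(=O)[nH]1` has not yet been measured. It differs from compound 3 in one place: 4-chlorophenyl in place of 3-methylphenyl on an aromatic nitrogen. Within the data shown here, no measured pair shows this exact exchange, so its size is not known. Among the measured compounds shown here, the 4-chlorophenyl group is the one carried by compound 1, the strongest of the three, but compound 1 also attaches the sulfonamide-bearing ring differently, so that comparison is only indirect. A modest gain in potency is expected, near the edge of the scatter, so that the step from compound 3 to compound 4 is estimated at a 1.7-fold lower number from compound 3 to compound 4 (0.24 log units; within the scatter). Compound 4 is accordingly expected to give about 4000 nM in this assay, within a range of 1500 nM to 11000 nM.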

Compound 4, half-maximal inhibitory concentration: 1210 nM
Compound 4: the middle estimate sits 3.3-fold (0.52 log units) above what was measured; measured number below the stated range.
By their numbers in this assay, from the lowest: compounds 1 and 4 (each within the scatter of the next); then compound 2; then compound 3.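

In this assay, the exchange of 3-methylphenyl for 4-chlorophenyl on the aromatic nitrogen of the five-membered ring gives a 5.8-fold lower number from compound 3 to compound 4 (0.76 log units; beyond the scatter) and so shows that the read-out responds to the group at this position, although the two groups have the same heavy-atom count and the same counts of hydrogen-bond donors and acceptors. This pair is the first among the compounds shown to differ in one place, which makes it the first direct reading of a change here. No measurement at hand accounts for the size of this step.

The compounds shown leave open whether the step follows the chlorine, its place on the ring or the removal of the methyl. Going by these compounds, how a plain phenyl, a 3-chlorophenyl or a 4-methylphenyl would read at this position also remains open.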